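The source may hold more compounds than are shown below. What is called first, only, known or untested is meant among the compounds shown, and "the series" means these compounds.

Compound 1 `CC[C@@H]1C(=O)N(C)c2cnc(-n3ccc4cc(F)ccc43)nc2N1C1CCCC1` has no single number to stand on: in a functional assay on MCF7 cells (Homo sapiens) for antiproliferative activity, read by CCK-8 assay, with a stated time of 72 h (a higher number here means a weaker inhibitor of growth, a lower number a stronger inhibitor of growth), compound 1 was reported as "not active" (no number reported). Two other compounds on the same core give numbers. Compound 2 `CC[C@@H]1C(=O)N(C)c2cnc(Nc3ccc(S(=O)(=O)NC4CCCC4)cc3)nc2N1C1CCCC1` reaches 688 nM in this assay, while compound 3 `CCC1C(=O)N(C)c2cnc(-n3ccc4cc(C(=O)NC(C)C)ccc43)nc2N1c1ccn(C)n1`, which carries isopropylcarbamoyl on its fused ring system, gives 8420 nM. Compound 4 `CCCNC(=O)c1ccc2c(ccn2-c2ncc3c(n2)N(C2CCCC2)[C@H](CC)C(=O)N3C)c1` differs from compound 1 by propylcarbamoyl in place of fluoro on an aromatic carbon, on an aromatic carbon of a six-membered aromatic ring of carbon only, part of a fused system of two rings. Among the measured compounds shown here, with no measured step to lean on, a gain beyond the scatter in this assay is expected, moving compound 4 from no detectable activity into a measurable range. Compound 4 is estimated at 3000 nM, expected between 700 nM and 15000 nM.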

Compound 4, concentration for 50% growth inhibition: 592 nM
Compound 4: middle estimate off by 5.1-fold (0.70 log units), on the high side; measured number outside the range, below it.
By their numbers in this assay, from the lowest: compounds 4 and 2 (each within the scatter of the next); then compound 3.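

Among the compounds shown here, compound 1 has no number, so no step from it to compound 4 can be read. The compounds shown leave open how far propylcarbamoyl in place of fluoro shifts growth inhibition. Nothing measured here explains the result.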